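Swapping a cyclopentyloxy for a methanesulfonamido group

The compounds below may be only part of what the source reports. "The series", "measured", "known", "first", "only" and "open" are said of these compounds alone.

Three compounds sharing one core were tested in an ADME assay on Vero cells (Chlorocebus sabaeus) for cytotoxicity, read by MTT assay, with a stated time of 72 h; a higher number here means a weaker inhibitor, a lower number a stronger inhibitor. Compound 1, `COc1cccc(-c2csc(NC(=O)c3ccc([N+](=O)[O-])cc3)n2)c1`, gives only a limit in this assay, > 90000 nM, and the reading the limit of > 90000 nM in this assay, at which 1 of the 3 values shown sits, marks how far that measurement reaches. Compound 2, `O=C(Nc1nc(-c2cccc(OC3CCCC3)c2)cs1)c1ccc([N+](=O)[O-])o1`, gives 81100 nM. Compound 3, `O=C(Nc1nc(-c2c(F)cc(F)cc2F)cs1)c1ccc([N+](=O)[O-])o1`, gives 19900 nM. Of the two actual numbers, compound 2 stands at the higher one, and its gap to compound 3 lies beyond the usual scatter, so compound 2 is the weaker inhibitor of the two.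

Compound 4, `CS(=O)(=O)Nc1cccc(-c2csc(NC(=O)c3ccc([N+](=O)[O-])o3)n2)c1`, has not yet been measured. It differs from compound 2 in one place: methanesulfonamido in place of cyclopentyloxy on an aromatic carbon. For the measured compounds named here, no pair of measured compounds here differs in just this way, so the size of the step is not known from data. For this kind of change, the expectation is a small move in this assay, if any, toward a higher number, and most likely not beyond the scatter; the possibility that compound 4 reaches the limit of the assay, as compound 1 does, cannot be excluded.

Compound 4 is therefore estimated at 85000 nM, with a range from 40000 nM to 160000 nM, which would mean an expected step of a 1.0-fold higher number from compound 2 to compound 4 (0.02 log units; within the scatter).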

Compound 4, half-maximal inhibitory concentration: < 2820 nM
Compound 4 gave a limit, no number; the forecaster's own chance of this, stated with the estimate: 40%; middle value at least 30-fold (1.47 log units) away from the limit.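

In this assay, this single change at one aromatic carbon turns out to matter a great deal, with methanesulfonamido in place of cyclopentyloxy giving an at least 28-fold lower number from compound 2 to compound 4 (1.45 log units; beyond the scatter). This pair is the only one shown that differs in just one place, so it offers the only direct reading of what this position tolerates, and it shows that the group on this carbon can strongly shift the effect on the cells toward stronger inhibition. Compound 4 gives a limit rather than an actual number, so the step has a known minimum but no known full size: the limit of < 2820 nM in this assay, at which 1 of the 4 values shown sits.

A single pair cannot tell whether the shift comes from losing the cyclopentyloxy ring or from gaining the methanesulfonamido group, and nothing measured here explains why the number falls. An amine or a carboxylic acid on the same aromatic carbon would help to separate these two readings, while the compounds shown also leave open whether the same swap would act alike on the core of compound 1.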